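This account rests on a few compounds, and the source may have more. Where it says the series, first, only, none or still open, it means among the compounds named here.

Measured compounds:
compound 2, `Nc1nc(NCc2ccc(F)cc2)nc(-c2ccccc2CO)n1`, 3.97
compound 1, `Nc1nc(NCc2ccccc2)nc(-c2ccc(F)cc2CO)n1`, 4.58
compound 3, `Nc1nc(NCc2ccc(C(F)(F)F)cc2)nc(-c2ccccc2CO)n1`, 5.03

In a functional assay on cells for positive allosteric modulation of G-protein coupled receptor 68 (Homo sapiens), read by a luciferase reporter and cAMP accumulation, with a stated time of 30 min, at pH 6.8 and pH 8.3, in the presence of a further agent that is not named here (a higher number here means a more potent compound, by a factor of ten per unit of this negative logarithm, a lower number a less potent compound), compound 2 stands lowest of the three measured compounds, with compound 1 nearest and compound 3 furthest above it. Compound 4, `Cc1cccc(CNc2nc(N)nc(-c3ccccc3CO)n2)c1`, differs from compound 2 by 3-methylphenyl in place of 4-fluorophenyl on a saturated chain carbon bound to a nitrogen on an aromatic ring. Within the data shown here, only one measured step bears on this change: a number 1.06 log units higher from compound 2 to compound 3 (beyond the scatter), where a group on the same benzyl ring was exchanged. That step shows this ring position can move the number strongly, but nothing is known for a methyl group or for the shift to the 3-position, so the direction is uncertain. Compound 4 is therefore expected to give 4.4, within 3.8 to 5, an estimated step of a number 0.43 log units higher from compound 2 to compound 4 (beyond the scatter).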

Compound 4, negative logarithm of the antagonist equilibrium constant: 4.4
Compound 4: middle estimate and measured number agree at the digits printed; measured number inside the range.
By their numbers in this assay, from the lowest: compound 2; then compounds 4 and 1 (each within the scatter of the next); then compound 3.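

In this assay, the change from 4-fluorobenzyl to 3-methylbenzyl gives a number 0.43 log units higher from compound 2 to compound 4 (beyond the scatter), so a rise at this benzyl ring does not depend on a fluorine-bearing group or on the trifluoromethyl of compound 3. Because group and ring place changed together in this one step, it cannot assign the rise to either alone. Nothing available here accounts for the step. As far as these compounds go, what remains open is how the methyl would read with its place on the ring unchanged, and how a methoxy group or an amine on this ring would behave.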